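The source may report more compounds than this note shows. Statements on the series, on what has been measured and on what is new or still open speak of the compounds shown alone.

Measured compounds:
- compound 1 `COc1ccccc1C(=O)/C=C/c1ccc2c(c1)B(O)OC2`, in a functional assay on SK-OV-3 cells (Homo sapiens) for cytotoxicity, read by MTT assay, with a stated time of 48 h (a higher number here means a weaker inhibitor, a lower number a stronger inhibitor), compound 1 gives 2600 nM
- compound 2 `COc1ccc(C(=O)/C=C/c2ccc3c(c2)B(O)OC3)c(OC)c1`, compound 2 gives 6100 nM
- compound 3 `COc1ccc(C(=O)/C=C/c2ccc3c(c2)B(O)OC3)cc1OC`, compound 3 gives 4800 nM

Compound 2 differs from compound 1 by methoxy in place of hydrogen on an aromatic carbon, and this change made a 2.3-fold higher number from compound 1 to compound 2 (0.37 log units; beyond the scatter). Compound 3 and compound 1 differ in more than one place, so the difference between the two cores is not broken down here; their numbers lie within the scatter of each other, as do those of compound 3 and compound 2.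

Compound 4 `COc1cc(C(=O)/C=C/c2ccc3c(c2)B(O)OC3)cc(OC)c1OC` is not yet measured. It differs from compound 3 by methoxy in place of hydrogen on an aromatic carbon. This is the same kind of change as that from compound 1 to compound 2, but the place is not identical: in compound 2 the entering methoxy sits meta to a methoxy group and para to a large group, whereas in compound 4 it sits ortho to a methoxy group, meta to a large group and meta to a methoxy group.

Among the compounds with values here, for this assay a step of about a 1.6-fold higher number from compound 3 to compound 4 (0.19 log units; within the scatter) is expected, resting on the single earlier step of a 2.3-fold higher number from compound 1 to compound 2 (0.37 log units; beyond the scatter), with wide uncertainty since the surroundings of the place differ. Compound 4 is therefore estimated at 7500 nM, between 3000 nM and 18000 nM.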

Compound 4, half-maximal inhibitory concentration: 5700 nM
Compound 4: middle estimate off by 1.3-fold (0.12 log units), on the high side; measured number inside the range.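

The change of methoxy in place of hydrogen on an aromatic carbon gives a 1.2-fold higher number from compound 3 to compound 4 (0.07 log units; within the scatter) in this assay, so on this core it produces no readable shift. Set beside the earlier step, the size of the change does not separate between the two cores, and nothing here argues against carrying it from one to the other: the same change on two cores in this assay, a 2.3-fold higher number (0.37 log units; beyond the scatter) from compound 1 to compound 2 and a 1.2-fold higher number (0.07 log units; within the scatter) from compound 3 to compound 4, 2.0-fold (0.30 log units) apart, within the scatter of two such steps

Within the data shown here, this does not establish that the step is the same on both cores, since only two steps are available, the entering methoxy has different surroundings in each, and one step lies beyond the scatter while the other lies within it.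

The only group varied in the compounds shown is methoxy, so it remains open whether an amine, a carboxylic acid or a longer alkoxy chain such as butoxy at these places would move the number in this assay. From the compounds shown here alone, whether the step would hold in other cell lines also remains open.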